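Moving the Methyl Around the Saturated Ring

A few compounds are considered here, and "the series" means these few. Any claim that something is new, unique, unknown or untested is made for them only; others in the source may bear on it.

Among the measured compounds shown here, compound 3 `COc1ccc2c(CCCN3CCC[C@@H](C)C3)cccc2c1` gives 1.35 nM in an assay on membranes from brain for displacement of a labelled ligand from Sigma non-opioid intracellular receptor 1 (Cavia porcellus) (a lower number here means a stronger inhibitor, a higher number a weaker inhibitor), the second highest of the three numbers known so far. Compound 1 `COc1ccc2c(c1)CCCC2CCCCN1CCC(C)(C)CC1` gives 0.3 nM, and compound 2 `COc1ccc2c(CCCN3CCC[C@H](C)C3)cccc2c1` gives 3.32 nM. For the measured compounds named here, the only measured step on the methyl-bearing ring is a 2.5-fold lower number from compound 2 to compound 3 (0.39 log units; beyond the scatter), which rests on (the fact that compounds 2 and 3 differ only in the configuration as drawn). Compound 4 `COc1ccc2c(CCCN3CCC(C)CC3)cccc2c1` differs from compound 3 in one place: 4-methylpiperidin-1-yl in place of 3-methylpiperidin-1-yl on a saturated chain carbon, three bonds along the chain from an aromatic carbon. The stereocentre thereby disappears. Going by the values given here, no measured step tests where the methyl sits on that ring, and the stereo step was modest, so in this assay a change of similar or smaller size is expected, with no clear direction beyond the scatter. Compound 4 is estimated at 1.3 nM, within a range from 0.4 nM to 4.5 nM. That expectation amounts to a 1.0-fold lower number from compound 3 to compound 4 (0.02 log units; within the scatter).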

Compound 4, inhibition constant: 1.5 nM
Beside the measured number, compound 4's estimate is 1.2-fold (0.06 log units) below it; the range from low to high includes it.
By their numbers in this assay, from the lowest: compound 1; then compounds 3 and 4 (each within the scatter of the next); then compound 2.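

Putting 4-methylpiperidin-1-yl in place of 3-methylpiperidin-1-yl gives a 1.1-fold higher number from compound 3 to compound 4 (0.05 log units; within the scatter), so in this assay this move of the methyl, which also removes the stereocentre, does not separate the two compounds. The same swap, set against the other drawn configuration, gives a 2.2-fold lower number from compound 2 to compound 4 (0.35 log units; beyond the scatter), a modest step. Among these three compounds, then, a defined stereocentre on the ring is not needed to reach the level of compound 3.

Still open, on these data alone, is whether piperidin-1-yl with no methyl, or morpholin-4-yl, would hold this level on the same chain.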